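A methyl gives way to bromo on compound 2

The source may report more compounds than this note shows. Statements on the series, on what has been measured and on what is new or still open speak of the compounds shown alone.

Of the compounds shown here, two have been tested so far in an in vivo ADME assay on the whole organism (Rattus norvegicus), at a dose of 2 mg/kg by the intravenous route; on this read-out lower numbers stand for narrower distribution and higher numbers for wider distribution into tissues. Compound 1 (`Clc1cncc(OC2C=C(C#Cc3ccccn3)CCC2)c1`) gives 1.4 L/kg. Compound 2 (`Cc1ccc(S(=O)(=O)N2CC=C(C#Cc3ccccn3)CC2)cc1`) gives 14.7 L/kg, the higher of the two numbers, and the gap between them lies beyond the usual scatter of repeated measurements. These two compounds differ in more than one place, so their gap cannot be pinned on any single group.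

Compound 3 (`O=S(=O)(c1ccc(Br)cc1)N1CC=C(C#Cc2ccccn2)CC1`) has not yet been measured. It differs from compound 2 by one swap: bromo in place of methyl on an aromatic carbon. In plain terms, this puts bromo in place of methyl on an aromatic carbon, para to a large group.

Among the compounds with values here, no measured pair of compounds shows what this swap does in this assay, so the expectation is a cautious one, anchored on compound 2 at 14.7 L/kg. The estimated step of a 1.1-fold lower number from compound 2 to compound 3 (0.02 log units; within the scatter) is expected to stay within the scatter, with no firm direction. For compound 3 the expected value is 14 L/kg, with an estimated range of 6 L/kg to 30 L/kg.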

Compound 3, volume of distribution: 3.98 L/kg
Compound 3: middle estimate off by 3.5-fold (0.55 log units), on the high side, and the stated range ends above it.
By their numbers in this assay, from the lowest: compound 1; then compound 3; then compound 2.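

In this assay, the swap from 4-methylphenyl to 4-bromophenyl produces a 3.7-fold lower number from compound 2 to compound 3 (0.57 log units; beyond the scatter). This shows that a change of one heavy atom on an aromatic carbon, para to a large group, can move the read-out by more than repeat measurements would be expected to, even though the counts of rings, hydrogen-bond donors, hydrogen-bond acceptors and net charge stay the same. It is also the first step here between compounds that differ in only one place, so this gap can be assigned to a single swap, unlike the gap between compound 1 and compound 2, but no measurement shown explains the drop.

Within the data shown here, a single pair gives only one step and no trend, so it remains open whether chloro, methoxy, an amine or a carboxylic acid at this position would give a number near that of compound 2, near that of compound 3, or outside both. Going by these compounds, it is equally open whether the same swap would produce a step of similar size and direction on a different core, such as the core of compound 1.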